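This account rests on a few compounds, and the source may have more. Where it says the series, first, only, none or still open, it means among the compounds named here.

In a functional assay for inhibition, read by spectrophotometry, with a stated time of 10 min, tested at 150 uM (on this read-out lower numbers stand for less inhibition and higher numbers for more inhibition at the one concentration tested (going by the name of the read-out)), the measured compounds stand as follows:
compound 1 `CCN(CC)C(=O)COc1cc(O)c2c(=O)c(O)c(-c3ccc4c(c3)OC(c3ccc(OCC(=O)N(CC)CC)c(OC)c3)C(CO)O4)oc2c1` gives 63%
compound 2 `COc1cc(C2Oc3cc(-c4oc5cc(OCC=C(C)C)cc(O)c5c(=O)c4O)ccc3OC2CO)ccc1O` gives 51%

Compound 2 is the lower of the two numbers; its nearest neighbour, compound 1, sits higher by a gap beyond the usual scatter. Compound 3 `CCN(CC)C(=O)COc1cc(O)c2c(=O)c(O)c(-c3ccc4c(c3)OC(c3ccc(O)c(OC)c3)C(CO)O4)oc2c1` has not been measured. It differs from compound 2 in one place: diethylcarbamoyl in place of 2-methylprop-1-en-1-yl on a saturated chain carbon bound to an oxygen on an aromatic ring. Going by the values given here, no measured pair shows this exact change, so the step of a number 7 percentage points higher from compound 2 to compound 3 (within the scatter) is expected to be modest and upward, near the edge of the scatter, because compound 1 gives 63% and itself carries a (diethylcarbamoyl)methoxy group. Compound 3 is accordingly estimated at 58%, within 45% to 70%.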

Compound 3, a percentage reported as inhibition, at one concentration (the size of the read-out at that concentration, not a potency): 52.5%
Compound 3: middle estimate off by 5.5 percentage points, on the high side, within the range that was stated.
By their numbers in this assay, from the lowest: compounds 2 and 3 (each within the scatter of the next); then compound 1.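

In this assay, diethylcarbamoyl in place of 2-methylprop-1-en-1-yl on a saturated chain carbon bound to an oxygen on an aromatic ring gives a number 1.5 percentage points higher from compound 2 to compound 3 (within the scatter), so the two groups cannot be told apart at this position. Hydrogen in place of (diethylcarbamoyl)methyl on an oxygen on an aromatic ring gives a number 10.5 percentage points lower from compound 1 to compound 3 (beyond the scatter), a change that does show in the read-out. Nothing here explains either result. Open, on these data alone, is whether an amine or a carboxylic acid in either place would shift the number. A single tested concentration also leaves potency unknown.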